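Returning an amide to the carbonyl carbon

The compounds below may be only part of what the source reports. "The series", "measured", "known", "first", "only" and "open" are said of these compounds alone.

Compound 1 `CCN(CC)CCNC(=O)c1ccc(C(CC)(CC)c2ccc(OCC(=O)C(C)(C)C)c(C)c2)n1CC` carries (2-(diethylamino)ethyl)amino on its carbonyl carbon, and in an assay on HL-60 cells for agonist activity at vitamin D3 receptor (Homo sapiens), read by microscopy, with a stated time of 96 h (a higher number here means that more compound is needed for the effect, a lower number that less compound is needed), compound 1 gives 91 nM. Among the compounds with values here, compound 2 `C#CCCOC(=O)c1ccc(C(CC)(CC)c2ccc(OCC(=O)C(C)(C)C)c(C)c2)n1CC` has (but-3-yn-1-yl)oxy in that place; in this assay compound 2 gives 28800 nM, the highest of the two numbers measured so far, and the step of a 320-fold higher number from compound 1 to compound 2 (2.50 log units; beyond the scatter) is large. Compound 3 `CCOc1ccc(NC(=O)c2ccc(C(CC)(CC)c3ccc(OCC(=O)C(C)(C)C)c(C)c3)n2CC)cc1` has not yet been measured. The change from compound 2 is (4-ethoxyphenyl)amino in place of (but-3-yn-1-yl)oxy on a carbonyl carbon. Within the data shown here, the one measured step that bears on this is a 320-fold higher number from compound 1 to compound 2 (2.50 log units; beyond the scatter), where an amide on this carbonyl carbon gave a far lower number than the ester; compound 3 brings an amide back, though with an aromatic substituent rather than the chain of compound 1, so how complete the return is cannot be read from a single pair. A large drop is nevertheless expected, a 96-fold lower number from compound 2 to compound 3 (1.98 log units; beyond the scatter). Compound 3 is therefore estimated at 300 nM in this assay, with a range from 50 nM to 3000 nM.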

Compound 3, half-maximal effective concentration: > 50000 nM
Compound 3: only a limit was reported; the forecaster's own chance of this, stated with the estimate: 5%; at least 160-fold (2.22 log units) between middle value and limit.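

Compound 3 gave only a limit rather than a number: the limit of > 50000 nM in this assay, at which 1 of the 3 values shown sits.

This shows that an amide on this carbonyl carbon does not by itself bring back the low number of compound 1, as the nitrogen is kept and only its substituent changes in the step of an at least 540-fold higher number from compound 1 to compound 3 (2.73 log units; beyond the scatter). The substituent on the amide-type nitrogen therefore matters greatly in this series, which the earlier pair could not show, as it changed the ester and the amide chain together. Against the ester, the reading is an at least 1.7-fold higher number from compound 2 to compound 3 (0.23 log units; that floor lies within the scatter), so the compounds shown do not establish that (4-ethoxyphenyl)amino is any worse than (but-3-yn-1-yl)oxy, and how far compound 3 lies beyond its limit stays unknown.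

The compounds shown leave open whether the low number of compound 1 rests on the diethylamino group or on the amide chain alone, and a plain butylamino group on the carbonyl carbon would separate the two. They also leave open whether a 2-(4-ethoxyphenyl)ethylamino group, which puts a chain before the aromatic ring, would behave like compound 1 or compound 3.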